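A triazolyl-to-oxazolyl exchange on a carbonyl carbon

A few compounds are considered here, and "the series" means these few. Any claim that something is new, unique, unknown or untested is made for them only; others in the source may bear on it.

Values in a physicochemical assay for lipophilicity, read by HPLC, measured as chromatographic lipophilicity, at pH 7.4 (on this read-out higher numbers stand for higher lipophilicity and lower numbers for lower lipophilicity), for three compounds:
- compound 1 `O=C(c1ccccc1)N1CCC(C(=O)N2N=CCC2c2ccccc2)CC1` gives 4.4
- compound 2 `CCC(=O)N1CCC(C(=O)N2N=CCC2c2ccccc2)CC1` gives 3.2
- compound 3 `O=C(c1c[nH]nn1)N1CCC(C(=O)N2N=CCC2c2ccccc2)CC1` gives 2

Compound 3 is the lowest of the three, and both steps down to it lie beyond the scatter. Compound 4 `O=C(c1cocn1)N1CCC(C(=O)N2N=CCC2c2ccccc2)CC1` has 1,3-oxazol-4-yl in place of 1H-1,2,3-triazol-4-yl on a carbonyl carbon. Three measured steps at this same place bear on it, all large: a number 1.20 log units lower from compound 1 to compound 2 (beyond the scatter) and a number 2.40 log units lower from compound 1 to compound 3 (beyond the scatter) and a number 1.20 log units lower from compound 2 to compound 3 (beyond the scatter) as well. None tests this exchange directly. Every measured step into compound 3 went down, so a large move upward is expected. The estimated step is a number 1.00 log units higher from compound 3 to compound 4 (beyond the scatter) in this assay as the expected outcome. For compound 4 the estimate is 3 with an expected range from 2.6 to 3.4 at its ends.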

Compound 4, distribution coefficient: 2.9
Compound 4: middle estimate off by 0.10 log units, on the high side; low and high end bracket the measured number.
By their numbers in this assay, from the lowest: compound 3; then compounds 4 and 2 (each within the scatter of the next); then compound 1.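

In this assay the exchange on the carbonyl carbon gives a number 0.90 log units higher from compound 3 to compound 4 (beyond the scatter), so two five-membered aromatic rings with the same heavy-atom count are not interchangeable at this position. Compound 4 is not separated from the ethyl compound, with a number 0.30 log units lower from compound 2 to compound 4 (within the scatter), but the phenyl compound stands apart, with a number 1.50 log units lower from compound 1 to compound 4 (beyond the scatter). The entering group has 0 hydrogen-bond donors where the leaving group has 1, yet nothing available here links that difference to the step. Open, on these data alone, is where a carboxylic acid, an amine or a pyridin-3-yl group on this carbonyl carbon would fall.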